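The source may report more compounds than this note shows. Statements on the series, on what has been measured and on what is new or still open speak of the compounds shown alone.

Compound 1, `CCOC(=O)c1c(-c2cccc(-c3ccccc3)c2)[nH]c2cc(OC)ccc2c1=O`, in an ADME assay on Raji cells (Homo sapiens) for cytotoxicity, read by luminescence, with a stated time of 72 h (a higher number here means that more compound is needed for the effect, a lower number that less compound is needed), gives only a limit, > 21500 nM.
Compound 2, `CCOC(=O)c1c(-c2cccc(OC(C)C)c2)[nH]c2cc(OC)ccc2c1=O`, in this assay gives only a limit, > 21500 nM.
Compound 3, `CCOC(=O)c1c(-c2cccc(C(C)=O)c2)[nH]c2cc(OC)ccc2c1=O`, in this assay gives only a limit, > 21500 nM.

Compound 2 therefore stands where every measured member of the series stands, at the limit of > 21500 nM in this assay, at which 3 of the 3 values shown sit. For the measured compounds named here, none of the measured steps can be read: a step that the two limits leave unreadable from compound 1 to compound 2, a step that the two limits leave unreadable from compound 1 to compound 3 and a step that the two limits leave unreadable from compound 2 to compound 3 all run from one limit to another, so neither their size nor their direction is known. The change that leads to compound 4, `CCOC(=O)c1c(-c2cccc(S(C)(=O)=O)c2)[nH]c2cc(OC)ccc2c1=O`, is methylsulfonyl in place of isopropoxy on an aromatic carbon. The step bearing most directly on it is a step that the two limits leave unreadable from compound 2 to compound 3, which exchanges the same isopropoxy at the same aromatic carbon, and it too is unreadable. Three different groups at this position leave the value at the limit, so no step beyond the scatter is expected in this assay in either direction. The expected step is a step that the limit leaves unreadable from compound 2 to compound 4, again without readable size. Compound 4 is estimated at 30000 nM, between 10000 nM and 100000 nM, most likely reported only as a limit.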

Compound 4, half-maximal effective concentration: > 21500 nM
Compound 4: only a limit was reported; the forecaster's own chance of this, stated with the estimate: 85%; the middle value does not contradict the limit.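

Compound 4 gives only a limit, > 21500 nM. Its steps from compound 1, compound 2 and compound 3 therefore cannot be read, in size or direction. The compounds shown leave open whether any group at this position gives a measurable value in this assay.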